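The source may report more compounds than this note shows. Statements on the series, on what has been measured and on what is new or still open speak of the compounds shown alone.

Measured so far, in an assay for inhibition of serine/threonine-protein kinase 4 (Homo sapiens), read by luminescence and ADP-Glo, in the presence of a further agent that is not named here; on this read-out lower numbers stand for stronger inhibition and higher numbers for weaker inhibition:
Compound 1 `CNC1CCN(c2ncnc3[nH]cc(-c4cccc(Cl)c4)c23)CC1` gives 148 nM.
Compound 2 `CC(CO)CN(C)c1ncnc2[nH]cc(-c3cccc(Cl)c3)c12` gives 38 nM.

Compound 2 stands lowest of the two numbers in this assay; the nearest is compound 1, and the gap between them is a 3.9-fold lower number from compound 1 to compound 2 (0.59 log units; beyond the scatter). Compound 3 `Clc1cccc(-c2c[nH]c3ncnc(NCC4CC4)c23)c1` keeps the shared core of compound 2 and changes one group on it: a group of 5 heavy atoms (4 carbon, 1 nitrogen; one three-membered non-aromatic ring of carbon only) in place of a group of 7 heavy atoms (5 carbon, 1 nitrogen, 1 oxygen; no ring), on an aromatic carbon. Among the measured compounds shown here, only one measured step exists, and it bears on this change only loosely. That step replaced a six-membered ring-containing group with an open chain, a 3.9-fold lower number from compound 1 to compound 2 (0.59 log units; beyond the scatter), whereas here an open chain gives way to the (cyclopropylmethyl)amino group. For the measured compounds named here, the measured step shows that the group on this aromatic carbon can move the number in this assay by a modest amount, but nothing among the measured compounds shows which direction this particular swap takes. The expectation for compound 3 is therefore a small step, a 1.6-fold higher number from compound 2 to compound 3 (0.20 log units; within the scatter), with a wide range around it. Compound 3 is estimated at 60 nM, between 15 nM and 250 nM.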

Compound 3, half-maximal inhibitory concentration: 140 nM
The estimate for compound 3 lay 2.3-fold (0.37 log units) below the measured number; low and high end bracket the measured number.
By their numbers in this assay, from the lowest: compound 2; then compounds 3 and 1 (each within the scatter of the next).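

In this assay, the direction of this swap is now clear: replacing the open chain of compound 2 with (cyclopropylmethyl)amino weakens inhibition (a 3.7-fold higher number from compound 2 to compound 3 (0.57 log units; beyond the scatter)). The new group also cannot be told apart from the much larger 4-(methylamino)piperidin-1-yl on the same aromatic carbon (a 1.1-fold lower number from compound 1 to compound 3 (0.02 log units; within the scatter)), so among these three compounds only the open chain of compound 2 stands apart, and the two groups that hold a ring give matching results despite their different rings and sizes. Nothing measured here gives a reason for this difference.

The compounds shown do not reveal which feature of the chain in compound 2 goes with its lower number, whether the hydroxyl, the branching methyl or the methyl on the nitrogen: compound 3 differs from it in all of these at once. As far as these compounds go, an open chain of similar length ending in a plain methyl instead of the hydroxyl, or one ending in a carboxylic acid, could help separate these features, and how either would behave in this assay remains open.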